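Thiophene Amide Variation on a Dimethoxyphenyl Imidazopyridine Core

The compounds below may be only part of what the source reports. "The series", "measured", "known", "first", "only" and "open" are said of these compounds alone.

Measured compounds: compound 1 `COc1ccc(-c2cn3cc(C4=CCN(S(=O)(=O)CCc5ccccc5)CC4)ccc3n2)cc1OC` gives 8080 nM in a functional assay on B16-F10 cells (Mus musculus) for antiproliferative activity, read by MTT assay, with a stated time of 48 h; a lower number here means a stronger inhibitor, a higher number a weaker inhibitor; compound 2 `COc1ccc(-c2cn3cc(C4=CCN(C(=O)c5cccc(C(F)(F)F)c5)CC4)ccc3n2)cc1OC` gives 7890 nM in the same assay.

Compound 2 shows the lowest of the two numbers, with compound 1 nearest, and the step of a 1.0-fold lower number from compound 1 to compound 2 (0.01 log units; within the scatter) lies within the scatter, so the two cannot be ordered. Compound 3 `COc1ccc(-c2cn3cc(C4=CCN(C(=O)c5cccs5)CC4)ccc3n2)cc1OC` has not yet been measured. It differs from compound 2 by thiophen-2-yl in place of 3-(trifluoromethyl)phenyl on a carbonyl carbon. Going by the values given here, only one measured step bears on this: exchanging phenethylsulfonyl for (3-(trifluoromethyl)phenyl)carbonyl on the ring amine left the number essentially unchanged, as a 1.0-fold lower number from compound 1 to compound 2 (0.01 log units; within the scatter) shows. Since a larger change at the same position produced no shift beyond the scatter, a further exchange of the aryl group on the carbonyl is expected to produce none either, and compound 3 is estimated at 8000 nM (range 3500 nM to 18000 nM), a step of a 1.0-fold higher number from compound 2 to compound 3 (0.01 log units; within the scatter).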

Compound 3, half-maximal inhibitory concentration: 19500 nM
For compound 3 the middle estimate is 2.4-fold (0.39 log units) below the measured one, outside the stated range (above it).
By their numbers in this assay, from the lowest: compounds 2 and 1 (each within the scatter of the next); then compound 3.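

In this assay, the aryl group on the carbonyl carbon proves able to move the number: thiophen-2-yl in place of 3-(trifluoromethyl)phenyl gives a modest step beyond the scatter (a 2.5-fold higher number from compound 2 to compound 3 (0.39 log units; beyond the scatter)), whereas the earlier exchange on the ring nitrogen stayed within it. The same holds against the sulfonyl compound, since (thiophen-2-yl)carbonyl in place of phenethylsulfonyl gives a 2.4-fold higher number from compound 1 to compound 3 (0.38 log units; beyond the scatter), so the amide nitrogen substituent is not interchangeable in every case. Nothing available explains this step.

The compounds shown leave open whether the change in the number follows from the loss of the trifluoromethyl group, the sulfur atom or the five-membered ring. An unsubstituted phenyl or a furan-2-yl group on the same carbonyl carbon would help to separate these.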